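This account rests on a few compounds, and the source may have more. Where it says the series, first, only, none or still open, it means among the compounds named here.

Working notes on the series.

The shared core is carried by compound 1 `N#Cc1ccc(N2CCN(C(=S)SCc3ccc(C(=O)Nc4ccccc4N)cc3)CC2)cc1`, compound 2 `Nc1ccccc1NC(=O)c1ccc(CSC(=S)N2CCN(c3ncccn3)CC2)cc1` and compound 3 `Nc1ccccc1NC(=O)c1ccc(CSC(=S)N2CCN(C3CCCCC3)CC2)cc1`. In a functional assay on MGC-803 cells (Homo sapiens) for antiproliferative activity, read by CCK-8 assay, with a stated time of 72 h, tested at 8 uM (on this read-out lower numbers stand for a weaker effect and higher numbers for a stronger effect at the one concentration tested), compound 1 gives 37.6%, compound 2 gives 64.8% and compound 3 gives 75.3%. Compound 3 therefore stands highest of the three: the step of a number 10.5 percentage points higher from compound 2 to compound 3 (beyond the scatter) sets it apart from compound 2, and the step of a number 37.7 percentage points higher from compound 1 to compound 3 (beyond the scatter) from compound 1. The remaining step, a number 27.2 percentage points higher from compound 1 to compound 2 (beyond the scatter), completes the picture.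

Compound 4 `Nc1ccccc1NC(=O)c1ccc(CSC(=S)N2CCN(c3cnccn3)CC2)cc1` is not yet measured. Its change from compound 3 is pyrazin-2-yl in place of cyclohexyl on an amine nitrogen in a ring. The step bearing most directly on it is a number 10.5 percentage points higher from compound 2 to compound 3 (beyond the scatter), which exchanged one six-membered aromatic ring with two nitrogens for cyclohexyl and gained modestly; the move to pyrazin-2-yl runs this exchange back toward an aromatic ring with two hetero atoms. A modest drop of about that size is expected in this assay, reading compound 2 as the closest guide because of 64.8%. For compound 4 the estimate is 64%, within 50% to 78%, i.e. an expected step of a number 11.3 percentage points lower from compound 3 to compound 4 (beyond the scatter).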

Compound 4, a percentage reported as inhibition, at one concentration (the size of the read-out at that concentration, not a potency): 80.5%
Estimate against measurement, compound 4: 16.5 percentage points below; the measured number lies above the stated range.
By their numbers in this assay, from the lowest: compound 1; then compound 2; then compounds 3 and 4 (each within the scatter of the next).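

In this assay the substituent on the amine nitrogen need not be a saturated ring to reach the top of the series: a number 5.2 percentage points higher from compound 3 to compound 4 (within the scatter), so cyclohexyl and pyrazin-2-yl cannot be told apart here. Exchanging one six-membered aromatic ring with 2 hetero atoms for another still counts, with a number 15.7 percentage points higher from compound 2 to compound 4 (beyond the scatter), so the class of ring alone does not set the number at this position, and a number 42.9 percentage points higher from compound 1 to compound 4 (beyond the scatter) leaves 4-cyanophenyl at the low end of the compounds shown. Nothing measured here accounts for these differences.

As far as these compounds go, whether a pyridin-2-yl ring with a single nitrogen, or a small group such as methyl or acetyl, holds the number at this position stays open. Also open, from the compounds shown here alone, is whether compound 3 and compound 4 would separate at other concentrations or in other cell lines.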